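The compounds below may be only part of what the source reports. "The series", "measured", "known", "first", "only" and "open" are said of these compounds alone.

Compound 1 `Cc1nc(Nc2ccc(Cl)cc2)sc1C(=O)/C=C/c1ccccc1` carries a 4-chlorophenyl on a nitrogen on an aromatic ring. In a functional assay on Bel-7402 cells (Homo sapiens) for cytotoxicity, read by MTT assay (a higher number here means a weaker inhibitor, a lower number a stronger inhibitor), compound 1 gives only a limit, > 25000 nM. Compound 2 `Cc1nc(Nc2cccc(Cl)c2)sc1C(=O)/C=C/c1ccccc1` differs from compound 1 by 3-chlorophenyl in place of 4-chlorophenyl on a nitrogen on an aromatic ring. In this assay compound 2 also gives only a limit, > 25000 nM. The step that the two limits leave unreadable from compound 1 to compound 2 therefore cannot be sized. Compound 3 `Cc1nc(Nc2ccc(Cl)cc2)sc1C(=O)/C=C/c1ccc(Cl)cc1` differs from compound 1 by chloro in place of hydrogen on an aromatic carbon, and this is the whole difference between the core of compound 3 and the core of compound 1. In this assay compound 3 again gives only a limit, > 25000 nM. The step that the two limits leave unreadable from compound 1 to compound 3 is likewise unreadable. Compound 4 `Cc1nc(Nc2cccc(Cl)c2)sc1C(=O)/C=C/c1ccc(Cl)cc1` is not yet measured; it differs from compound 3 by 3-chlorophenyl in place of 4-chlorophenyl on a nitrogen on an aromatic ring, the same change, at the same place, as from compound 1 to compound 2. Every value shown sits at the limit of > 25000 nM in this assay, at which 3 of the 3 values shown sit, which gives no direction for the change. Compound 4 is expected to show a step that the limit leaves unreadable from compound 3 to compound 4 of no readable size, remaining at a limit. The estimate for compound 4 is 50000 nM, expected between 25000 nM and 200000 nM.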

Compound 4, half-maximal inhibitory concentration: > 25000 nM
Compound 4: a limit, no number (the forecaster's own chance of this, stated with the estimate: 85%); the middle value does not contradict the limit.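

Compound 4 also gives only a limit in this assay, so its steps from compound 3 and from compound 2 cannot be read: the limit of > 25000 nM in this assay, at which 4 of the 4 values shown sit. The compounds shown leave open whether 3-chlorophenyl in place of 4-chlorophenyl, or chloro in place of hydrogen on an aromatic carbon, changes the reading at all.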